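Aryl exchange on thioether side chains, monoamine oxidase B series

A few compounds are considered here, and "the series" means these few. Any claim that something is new, unique, unknown or untested is made for them only; others in the source may bear on it.

Measured so far:
compound 1, `C#CCNC1CCc2c(SCCc3ccc(C)cc3)cccc21`: 25800 nM in an assay on isolated protein for inhibition of Amine oxidase [flavin-containing] B (Homo sapiens); on this read-out higher numbers stand for weaker inhibition and lower numbers for stronger inhibition
compound 2, `C#CCNC1CCc2c(SCCc3cccc(Cl)c3)cccc21`: 82400 nM in this assay
compound 3, `C#CCNC1CCc2c(SCc3ccc(C)cc3)cccc21`: 1560 nM in this assay

Compound 3 gives the lowest of the three numbers. Its nearest neighbour is compound 1; the difference between the core of compound 3 and that of compound 1 is not broken down here. From compound 1 to compound 2 the change is 3-chlorophenyl in place of 4-methylphenyl on a saturated chain carbon, two bonds along the chain from a sulfur, and the step is a 3.2-fold higher number from compound 1 to compound 2 (0.50 log units; beyond the scatter).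

Compound 4, `C#CCNC1CCc2c(SCc3cccc(Cl)c3)cccc21`, is not yet measured and relates to compound 3 through (3-chlorophenyl in place of 4-methylphenyl on a saturated chain carbon bound to a sulfur). The place is not identical: in compound 4 the group sits on a saturated chain carbon bound to a sulfur, in compound 2 on a saturated chain carbon, two bonds along the chain from a sulfur, so this is the same kind of change, not the same change. Among the measured compounds shown here, for compound 4 a step of a 3.2-fold higher number from compound 3 to compound 4 (0.51 log units; beyond the scatter) in this assay is expected, because a 3.2-fold higher number from compound 1 to compound 2 (0.50 log units; beyond the scatter) is the only precedent, widened for the different place. Compound 4 is thus estimated at 5000 nM, expected between 1800 nM and 14000 nM.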

Compound 4, half-maximal inhibitory concentration: 23300 nM
Compound 4: the middle estimate sits 4.7-fold (0.67 log units) below what was measured; measured number outside the range, above it.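

In this assay the exchange of 4-methylphenyl for 3-chlorophenyl on a saturated chain carbon bound to a sulfur gives a 15-fold higher number from compound 3 to compound 4 (1.17 log units; beyond the scatter). The direction of the change carries over from one core to the other, but its size does not: the same change on two cores in this assay, a 3.2-fold higher number (0.50 log units; beyond the scatter) from compound 1 to compound 2 and a 15-fold higher number (1.17 log units; beyond the scatter) from compound 3 to compound 4, 4.7-fold (0.67 log units) apart, beyond the scatter of two such steps. With only these two pairs, the notes show that a step measured on one core is a poor guide to its size on the other, but not what sets the size or how it would behave on a third core.

From the compounds shown here alone, it remains open whether the step follows the chlorine or the ring position, which 4-chlorophenyl and 3-methylphenyl on both cores would separate. Going by these compounds, the effect of the same exchange with an ether oxygen in place of the sulfur also remains open.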